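The source may report more compounds than this note shows. Statements on the series, on what has been measured and on what is new or still open speak of the compounds shown alone.

Of the compounds shown here, three have been measured in a functional assay on HepG2 cells (Homo sapiens) for cytotoxicity, read by sulforhodamine B assay, with a stated time of 48 h (on this read-out lower numbers stand for stronger inhibition and higher numbers for weaker inhibition), all sharing a sulfonamide-bearing hydrazone unit. Compound 1 `C/C(=N\NC(=O)CC#N)c1ccc(NS(=O)(=O)c2ccc(Cl)cc2)cc1` gives 8000 nM in this assay. Among the measured compounds shown here, compound 2 `C/C(=N\NC(=O)C(C#N)C(=S)S)c1ccc(NS(=O)(=O)c2ccc(Cl)cc2)cc1` differs from compound 1 only at one chain carbon; compound 2 gives 17500 nM, and the step of a 2.2-fold higher number from compound 1 to compound 2 (0.34 log units; beyond the scatter) is the single one-change comparison among the measured compounds. Compound 3 `CCOC(=O)c1c(-c2ccc(C)cc2)c(C#N)c(=O)n(/N=C(\C)c2ccc(NS(=O)(=O)c3ccc(Cl)cc3)cc2)c1N` carries a much larger ring-bearing substituent on the hydrazone nitrogen and gives 8380 nM, a number that sits close to that of compound 1, within the scatter, while the number for compound 2 is higher than that of compound 3 by an amount beyond the scatter.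

Compound 4 `CCOC(=O)c1c(-c2ccc(Cl)cc2)c(C#N)c(=O)n(/N=C(\C)c2ccc(NS(=O)(=O)c3ccc(Cl)cc3)cc2)c1N` is the unmeasured partner of compound 3. The change is chloro in place of methyl on an aromatic carbon. For the measured compounds named here, no measured step touches this part of the molecule: the one available step, from compound 1 to compound 2, concerns a chain carbon elsewhere, so it gives no direct guide to a methyl-for-chloro swap on an aromatic ring. With nothing pointing in either direction, the expectation is a step of about a 1.0-fold lower number from compound 3 to compound 4 (0.02 log units; within the scatter), that is, none beyond the scatter. Compound 4 is therefore estimated at 8000 nM, with a range from 4000 nM to 16000 nM.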

Compound 4, half-maximal inhibitory concentration: 20200 nM
For compound 4 the middle estimate is 2.5-fold (0.40 log units) below the measured one, outside the stated range (above it).
By their numbers in this assay, from the lowest: compounds 1 and 3 (each within the scatter of the next); then compounds 2 and 4 (each within the scatter of the next).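

In this assay, the change from 4-methylphenyl to 4-chlorophenyl gives a 2.4-fold higher number from compound 3 to compound 4 (0.38 log units; beyond the scatter), so a swap of a single atom at this aromatic carbon, para to a large group, is enough to shift the number beyond the scatter. Among the compounds shown here, the only earlier step concerned a chain carbon, so this is the first sign that the group on this aromatic ring matters to the read-out, and here chloro goes with weaker inhibition than methyl. The compounds shown offer no independent measurement that could explain this shift, so its cause remains unknown.

This is a single pair, so it cannot show whether the higher number comes with chloro itself or with the departure of methyl, and a plain hydrogen, a fluoro, a methoxy or an amine at the same carbon would help separate those two readings. It also leaves open whether a larger group such as a carboxylic acid or a longer chain would push the number further in the same direction or reverse it.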